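The source may report more compounds than this note shows. Statements on the series, on what has been measured and on what is new or still open speak of the compounds shown alone.

Of the compounds shown here, two built on one shared core have so far been measured in a functional assay on A-375 cells (Homo sapiens) for antiproliferative activity, read by MTT assay, with a stated time of 24 h, tested at 33.33 ug/mL; on this read-out higher numbers stand for a stronger effect at the one concentration tested and lower numbers for a weaker effect. Compound 1 `Cc1ccc2nc(C(=O)Nc3c(F)cc(-c4cccc(F)c4)cc3F)c(C)c(O)c2c1` gives 26.5% in this assay. Compound 2 `Cc1ccc2nc(C(=O)Nc3c(F)cc(-c4cccc(F)c4)cc3F)c(C)c(C(=O)O)c2c1` gives 26.3% in this assay. For the measured compounds named here, the only step measured between them, a number 0.2 percentage points lower from compound 1 to compound 2 (within the scatter), accompanies a carboxy in place of hydroxy on an aromatic carbon and leaves the read-out essentially unchanged. Going by the values given here, compound 2 therefore stands level with compound 1, its sole measured neighbour, the two numbers lying within the scatter of each other.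

Compound 3 `Cc1c(C(=O)Nc2c(F)cc(-c3cccc(F)c3)cc2F)nc2ccc(F)cc2c1C(=O)O` has not yet been measured. It differs from compound 2 by fluoro in place of methyl on an aromatic carbon. Among the compounds with values here, no measured step concerns a fluoro in place of methyl at this place, so the two numbers at hand give no ground to foresee a shift in either direction beyond the scatter. Compound 3 is accordingly expected to give about 26% in this assay, with an expected range from 14% to 38%. This expectation amounts to an estimated step of a number 0.3 percentage points lower from compound 2 to compound 3 (within the scatter).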

Compound 3, a percentage reported as inhibition, at one concentration (the size of the read-out at that concentration, not a potency): 41.3%
Estimate against measurement, compound 3: 15.3 percentage points below; measured number outside the range, above it.
By their numbers in this assay, from the lowest: compounds 2 and 1 (each within the scatter of the next); then compound 3.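

With this assay, this position on the aromatic carbon, meta to a fused ring and para to a fused ring, proves to be one where a single exchange moves the read-out: fluoro in place of methyl gives a number 15 percentage points higher from compound 2 to compound 3 (beyond the scatter). This is the first step shown to lie beyond the scatter, since the carboxy in place of hydroxy step had left the read-out unchanged. The computed counts offer no distinction, as neither methyl nor fluoro carries a ring, a hydrogen-bond donor or acceptor, or a net charge, and nothing available explains the rise.

The compounds shown leave open whether the rise is particular to fluoro or would also appear with chloro, methoxy or a bare hydrogen at this place. They also leave open whether fluoro has the same effect when hydroxy stands in place of carboxy.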